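A few compounds are considered here, and "the series" means these few. Any claim that something is new, unique, unknown or untested is made for them only; others in the source may bear on it.

Measured compounds in an ADME assay on MT4 cells (Homo sapiens) for cytotoxicity, read by MTT assay; a higher number here means that more compound is tolerated, a lower number that less compound is tolerated:

Compound 1, `O=C1c2ccccc2C(=O)N1CCOC(=S)N(C(=O)c1c(F)cccc1F)c1ccc(Cl)cc1`: compound 1 gives 39000 nM
Compound 2, `O=C1c2ccccc2C(=O)N1CCOC(=S)N(C(=O)c1cc(Cl)cc(Cl)c1)c1ccc(Cl)cc1`: compound 2 gives 32000 nM
Compound 3, `O=C1c2ccccc2C(=O)N1CCOC(=S)N(C(=O)c1ccc(Cl)c([N+](=O)[O-])c1)c1ccc(Cl)cc1`: compound 3 gives 48000 nM

Compound 3 holds the highest of the three numbers, but its neighbours sit close: a 1.2-fold higher number from compound 1 to compound 3 (0.09 log units; within the scatter) and a 1.5-fold higher number from compound 2 to compound 3 (0.18 log units; within the scatter), so no real order can be read among the three. The third step, a 1.2-fold lower number from compound 1 to compound 2 (0.09 log units; within the scatter), is also within the scatter.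

Compound 4, `Cc1ccc(N(C(=O)c2ccc(Cl)c([N+](=O)[O-])c2)C(=S)OCCN2C(=O)c3ccccc3C2=O)cc1`, differs from compound 3 in one place: methyl in place of chloro on an aromatic carbon. For the measured compounds named here, none of the measured steps touches this position; all three vary the group on the carbonyl carbon, and the group carrying the chloro that now leaves is the same in compounds 1, 2 and 3. The steps that are known all remain within the scatter, which points to a series that barely responds in this assay to changes of an aromatic substituent. On that basis compound 4 is expected to show no step beyond the scatter, a 1.1-fold lower number from compound 3 to compound 4 (0.06 log units; within the scatter). Compound 4 is therefore estimated at 42000 nM, with a range from 20000 nM to 90000 nM.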

Compound 4, half-maximal cytotoxic concentration: 47000 nM
Compound 4: middle estimate off by 1.1-fold (0.05 log units), on the low side; measured number inside the range.
By their numbers in this assay, from the lowest: compounds 2, 1, 4 and 3 (each within the scatter of the next).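

In this assay, methyl in place of chloro gives a 1.0-fold lower number from compound 3 to compound 4 (0.01 log units; within the scatter), the first step shown at the group that stayed 4-chlorophenyl throughout compounds 1, 2 and 3. The lack of response seen so far for the group on the carbonyl carbon therefore extends, among these four compounds, to a second place: the aromatic carbon para to a large group, where the 4-chlorophenyl to 4-methylphenyl exchange leaves no step that can be read beyond the scatter. Nothing measured here gives a reason for this result.

Only chloro and methyl are shown at this position, so it remains open whether an amine, a carboxylic acid or a longer chain there would give a step beyond the scatter. On these data alone, it is also open whether the same exchange would read alike with 2,6-difluorophenyl or 3,5-dichlorophenyl on the carbonyl carbon.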